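Six-Membered Ring Swapped Back in at One Carbon

A few compounds are considered here, and "the series" means these few. Any claim that something is new, unique, unknown or untested is made for them only; others in the source may bear on it.

Compound 2 `Oc1cccc(-c2cc(-c3ccc(Cl)cc3)nc(-c3ccsc3)c2)c1` gives 11.7% in an assay on isolated protein for inhibition of DNA topoisomerase 1 (Homo sapiens), with a stated time of 30 min, tested at 100 uM; on this read-out lower numbers stand for a weaker effect and higher numbers for a stronger effect at the one concentration tested. Going by the values given here, its only measured companion is compound 1 `Oc1cccc(-c2cc(-c3ccc(Cl)cc3)nc(-c3cccnc3)c2)c1`, which in this assay gives 2.8%; the two numbers lie within the scatter of one another, so neither can be called the stronger. Among the compounds with values here, the single known step, a number 8.9 percentage points higher from compound 1 to compound 2 (within the scatter), is the only guide available. Compound 3 `Oc1cccc(-c2cc(-c3ccc(Cl)cc3)nc(-c3ccccn3)c2)c1` has not yet been measured in this assay. It differs from compound 2 in one place: pyridin-2-yl in place of thiophen-3-yl on an aromatic carbon. The known step bears on this change in that it, too, exchanged the group on that same aromatic carbon, and it amounted to a number 8.9 percentage points higher from compound 1 to compound 2 (within the scatter), which is within the scatter. With pyridin-2-yl sharing its six-membered ring and one nitrogen with the pyridin-3-yl of compound 1, no step beyond the scatter is expected, and the expected shift from compound 2 to compound 3 is a number 5.7 percentage points lower from compound 2 to compound 3 (within the scatter). Compound 3 is therefore estimated at 6% in this assay, with a range from -5% to 20%.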

Compound 3, a percentage reported as inhibition, at one concentration (the size of the read-out at that concentration, not a potency): 30%
The estimate for compound 3 lay 24 percentage points below the measured number, and the stated range ends below it.
By their numbers in this assay, from the lowest: compounds 1 and 2 (each within the scatter of the next); then compound 3.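

In this assay, going by these compounds alone, the aromatic carbon next to the ring nitrogen proves able to move the read-out: pyridin-2-yl in place of thiophen-3-yl gives a number 18.3 percentage points higher from compound 2 to compound 3 (beyond the scatter), the first step at this place that clears the scatter. The comparison between the two pyridines is the more telling one, since pyridin-2-yl in place of pyridin-3-yl gives a number 27.2 percentage points higher from compound 1 to compound 3 (beyond the scatter), so a six-membered aromatic ring with 1 hetero atom does not by itself set the number, and compound 1, which carries such a ring, goes against any reading based on ring size alone. Nothing available explains why pyridin-2-yl stands apart from the other two groups.

The compounds shown leave open whether a pyridin-4-yl, a plain phenyl or a pyridin-2-yl carrying an amine would raise or lower the number at this carbon. They also leave open whether the gain from pyridin-2-yl survives changes to the 3-hydroxyphenyl or 4-chlorophenyl groups, and, with each number read at a single concentration, whether the stronger effect of compound 3 at that concentration would hold at any other.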